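Swapping Methyl for Fluoro on Two Related Cores

This account rests on a few compounds, and the source may have more. Where it says the series, first, only, none or still open, it means among the compounds named here.

Three compounds have been measured in a functional assay on NCI-H460 cells (Homo sapiens) for cytotoxicity, read by MTT assay, with a stated time of 72 h; on this read-out higher numbers stand for weaker inhibition and lower numbers for stronger inhibition:

Compound 1 `COc1cc2c(Oc3ccc(NC(=O)c4cc(-c5ccc(C)cc5)ccn4)cc3F)ccnc2cc1OCCCN1CCCC1` gives 160 nM.
Compound 2 `COc1cc2c(Oc3ccc(NC(=O)c4cc(-c5ccc(F)cc5)ccn4)cc3F)ccnc2cc1OCCCN1CCCC1` gives 370 nM.
Compound 3 `COc1cc2c(Oc3ccc(NC(=O)c4nccc(-c5ccc(C)cc5)n4)cc3F)ccnc2cc1OCCCN1CCCCC1` gives 230 nM.

Compound 2 differs from compound 1 in one place only, (fluoro in place of methyl on an aromatic carbon), and that single change raised the number: a 2.3-fold higher number from compound 1 to compound 2 (0.36 log units; beyond the scatter). Compound 3 shares much of its shape with compound 1, but the difference between the two cores is not broken down here. The values of compound 3 and compound 1 lie within the usual scatter of each other, and so do those of compound 3 and compound 2, so no order can be read among them.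

Compound 4 `COc1cc2c(Oc3ccc(NC(=O)c4nccc(-c5ccc(F)cc5)n4)cc3F)ccnc2cc1OCCCN1CCCCC1` has not yet been measured. For the measured compounds named here, it differs from compound 3 by fluoro in place of methyl on an aromatic carbon, which is the same change, at the same place, as the one separating compound 1 and compound 2. On the core of compound 3 the step from compound 3 to compound 4 is expected to be a 2.2-fold higher number from compound 3 to compound 4 (0.34 log units; beyond the scatter), because the earlier step read a 2.3-fold higher number from compound 1 to compound 2 (0.36 log units; beyond the scatter). The estimate for compound 4 in this assay is therefore 500 nM, with a likely range from 250 nM to 1000 nM.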

Compound 4, half-maximal inhibitory concentration: 240 nM
Compound 4: the middle estimate sits 2.1-fold (0.32 log units) above what was measured, outside the stated range (below it).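

On the core of compound 3, replacing 4-methylphenyl with 4-fluorophenyl in this assay gives a 1.0-fold higher number from compound 3 to compound 4 (0.02 log units; within the scatter), so this step, unlike the one on the core of compound 1, cannot be told apart from the usual variation between repeat measurements. Even so, the two steps cannot be said to disagree, since the gap between them is no larger than such variation allows: the same change on two cores in this assay, a 2.3-fold higher number (0.36 log units; beyond the scatter) from compound 1 to compound 2 and a 1.0-fold higher number (0.02 log units; within the scatter) from compound 3 to compound 4, 2.2-fold (0.35 log units) apart, within the scatter of two such steps. The pairs therefore do not show that the core changes the effect of this swap, and they do not show that the effect carries over intact, as a single pair on each core cannot separate a small real difference from scatter.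

The compounds shown leave open how other groups in the same place, such as chloro, trifluoromethyl, methoxy or an amine, would behave on either core. They also leave open whether a further pair on another related core would side with the larger step or the smaller one.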